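Sulfonyl substituent series: pentan-3-yl to isopropyl

The source may hold more compounds than are shown below. What is called first, only, known or untested is meant among the compounds shown, and "the series" means these compounds.

Among the compounds with values here, compound 2 `CCC(CC)S(=O)(=O)c1ccc(S(=O)(=O)N2CCC[C@@H](C(=O)N3CCC(F)(F)CC3)C2)cc1` holds the highest of the two numbers so far in an ADME assay on microsomes from liver (Homo sapiens) for metabolic stability, read by LC-MS, using NADPH, with a stated time of 60 min, tested at 10 uM (a higher number here means that the compound lasts longer, a lower number that the compound disappears faster), where compound 2 gives 0.285 h; compound 1 `CCN(CC)S(=O)(=O)c1ccc(S(=O)(=O)N2CCC[C@@H](C(=O)N3CCC(F)(F)CC3)C2)cc1` gives 0.0457 h. Within the data shown here, the only measured step, a 6.2-fold higher number from compound 1 to compound 2 (0.79 log units; beyond the scatter), concerns the same sulfonyl sulfur and is the sole guide here. Compound 3 `CC(C)S(=O)(=O)c1ccc(S(=O)(=O)N2CCC[C@@H](C(=O)N3CCC(F)(F)CC3)C2)cc1` differs from compound 2 by isopropyl in place of pentan-3-yl on a sulfonyl sulfur. That step is not a repeat of the measured one, so no direction beyond the scatter is firmly expected; a small drop is the working guess, with compound 3 estimated at 0.15 h (range 0.06 h to 0.4 h), i.e. an expected 1.9-fold lower number from compound 2 to compound 3 (0.28 log units; within the scatter).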

Compound 3, half-life: > 1 h
Compound 3: no number, only a limit; the forecaster's own chance of this, stated with the estimate: 5%; at least 6.6-fold (0.82 log units) between middle value and limit.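

Isopropyl in place of pentan-3-yl on the sulfonyl sulfur gives an at least 3.5-fold higher number from compound 2 to compound 3 (0.54 log units; beyond the scatter) in this assay, so this position separates two all-carbon groups, not only diethylamino from carbon groups. Set against diethylamino, isopropyl gives an at least 21-fold higher number from compound 1 to compound 3 (1.34 log units; beyond the scatter). Compound 3 stands at a limit, so neither step has a fixed size: the limit of > 1 h in this assay, at which 1 of the 3 values shown sits.

On these data alone, how far compound 3 lies beyond that limit stays open. Also open, as far as these compounds go, is whether methyl, ethyl or cyclopropyl on the same sulfur would match isopropyl in half-life.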